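From compound 3 to compound 4: an aryl exchange

A few compounds are considered here, and "the series" means these few. Any claim that something is new, unique, unknown or untested is made for them only; others in the source may bear on it.

Among the compounds with values here, the series so far holds compound 1 `C[C@H]1CC[C@@H]2[C@@H](OC(=O)[C@]23CC(c2ccc(Cl)cc2)=NO3)[C@]2(C)C(=O)C=C[C@@]12O`, compound 2 `C[C@H]1CC[C@@H]2[C@@H](OC(=O)[C@]23CC(c2ccccc2Br)=NO3)[C@]2(C)C(=O)C=C[C@@]12O` and compound 3 `C[C@H]1CC[C@@H]2[C@@H](OC(=O)[C@]23CC(c2ccccc2[N+](=O)[O-])=NO3)[C@]2(C)C(=O)C=C[C@@]12O`, which share one core and differ only in the aryl group on a carbon with a double bond to nitrogen. In a functional assay on SW-620 cells (Homo sapiens) for cytotoxicity, read by sulforhodamine B assay, with a stated time of 48 h (a lower number here means a stronger inhibitor, a higher number a weaker inhibitor), compound 1 gives 51000 nM, compound 2 gives 44000 nM and compound 3 gives 40000 nM. Compound 3 therefore stands level with both others, within the scatter of each. Next is compound 4 `COc1ccc(C2=NO[C@]3(C2)C(=O)O[C@@H]2[C@H]3CC[C@H](C)[C@]3(O)C=CC(=O)[C@@]23C)cc1OC`, with 3,4-dimethoxyphenyl in place of 2-nitrophenyl on that carbon: 3,4-dimethoxyphenyl in place of 2-nitrophenyl on a carbon with a double bond to nitrogen. The measured steps that bear on this are aryl exchanges at the same place: a 1.3-fold lower number from compound 1 to compound 3 (0.11 log units; within the scatter), a 1.2-fold lower number from compound 1 to compound 2 (0.06 log units; within the scatter) and a 1.1-fold lower number from compound 2 to compound 3 (0.04 log units; within the scatter), all within the scatter. Across 4-chlorophenyl, 2-bromophenyl and 2-nitrophenyl, this assay has so far separated nothing, and no compound goes against that. Within the data shown here, no measured compound carries a methoxy group, so this aryl group remains untested. No step beyond the scatter is expected, in either direction. The expected result is a 1.1-fold higher number from compound 3 to compound 4 (0.03 log units; within the scatter). For compound 4 the estimated value is 43000 nM, with an expected range of 20000 nM to 90000 nM.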

Compound 4, half-maximal inhibitory concentration: 86000 nM
Compound 4: the middle estimate sits 2.0-fold (0.30 log units) below what was measured; the measured number falls inside the stated range.
By their numbers in this assay, from the lowest: compounds 3, 2, 1 and 4 (each within the scatter of the next, the first and the last beyond it).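

In this assay this position on the carbon with a double bond to nitrogen now shows its first step beyond the scatter, though a modest one (a 2.2-fold higher number from compound 3 to compound 4 (0.33 log units; beyond the scatter)). The other two new steps (a 2.0-fold higher number from compound 2 to compound 4 (0.29 log units; within the scatter) and a 1.7-fold higher number from compound 1 to compound 4 (0.23 log units; within the scatter)) stay within the scatter, so 3,4-dimethoxyphenyl is set apart from 2-nitrophenyl only, and not from 2-bromophenyl or 4-chlorophenyl. Nothing measured here accounts for the separation from 2-nitrophenyl.

The compounds shown leave open whether any aryl exchange at this position can lower the number beyond the scatter, since the only step beyond it goes to a higher number, and whether a single methoxy group on the phenyl ring would give the same step as 3,4-dimethoxyphenyl. Also open, from the compounds shown here alone, is how this assay would respond to a phenyl ring bearing an amine or a carboxylic acid, or to a longer alkyl chain in place of the aryl group on that carbon.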